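Working notes on one series: aryl substituent swaps

The source may hold more compounds than are shown below. What is called first, only, known or untested is meant among the compounds shown, and "the series" means these compounds.

Measured so far:
compound 1, `CCOC(=O)C1=Cc2ccccc2OC1(OCc1cc(-c2ccc(OC)cc2)no1)C(F)(F)F`;
compound 2, `CCOC(=O)C1=Cc2ccccc2OC1(OCc1cc(-c2ccc3ccccc3c2)no1)C(F)(F)F`;
compound 3, `CCOC(=O)C1=Cc2ccccc2OC1(OCc1cc(-c2ccc([N+](=O)[O-])cc2)no1)C(F)(F)F`.

In a functional assay on DU-145 cells (Homo sapiens) for inhibition, read by MTT assay, with a stated time of 24 h (a higher number here means a weaker inhibitor, a lower number a stronger inhibitor), compound 1 gives only a limit, > 150000 nM. Compound 2 gives 71800 nM in this assay. Compound 3 gives only a limit in this assay, > 150000 nM, so compound 3 sits at the limit of > 150000 nM in this assay, at which 2 of the 3 values shown sit, with no number of its own. Compound 4, `CCOC(=O)C1=Cc2ccccc2OC1(OCc1cc(-c2ccc(C)cc2)no1)C(F)(F)F`, is not yet measured; it differs from compound 3 by methyl in place of nitro on an aromatic carbon. The steps that touch compound 3 are an at least 2.0-fold higher number from compound 2 to compound 3 (0.31 log units; beyond the scatter) and a step that the two limits leave unreadable from compound 1 to compound 3; neither shows how far past the limit compound 3 lies, so the size of the coming step is not readable from them. Compound 1 also sits at the limit, and a methyl is expected to stay near it. Compound 4 is therefore expected to give 150000 nM (range 60000 nM to 400000 nM), an expected step of a number no higher from compound 3 to compound 4 (the limit leaves the size open).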

Compound 4, half-maximal inhibitory concentration: > 150000 nM
Compound 4 gave a limit, no number; the forecaster's own chance of this, stated with the estimate: 60%; the middle value lies on the limit itself.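

In this assay compound 4 gives > 150000 nM, which is a limit and not a number. Among the compounds shown here, putting 4-methylphenyl in place of naphthalen-2-yl gives an at least 2.0-fold higher number from compound 2 to compound 4 (0.31 log units; beyond the scatter), so compound 2 remains the only one with a number of its own. The steps among compound 1, compound 3 and compound 4 cannot be read, and methyl joins methoxy and nitro at one limit: the limit of > 150000 nM in this assay, at which 3 of the 4 values shown sit.

How far past the limit each of these compounds lies stays open. Also open, going by these compounds, is whether an amine or a carboxylic acid in place of the methyl would give a number.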